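Working notes: from compound 3 to compound 4

The compounds below may be only part of what the source reports. "The series", "measured", "known", "first", "only" and "open" are said of these compounds alone.

In a functional assay on MCF7 cells (Homo sapiens) for inhibition, read by MTT assay, with a stated time of 48 h, tested at 10 uM (on this read-out higher numbers stand for more inhibition of growth at the one concentration tested and lower numbers for less inhibition of growth), compound 1 (`Cc1oc2c([C@H]3CCN(C)C[C@H]3O)c(O)cc(O)c2c(=O)c1C(O)c1ccc(Cl)cc1`) gives 6%, compound 2 (`Cc1oc2c([C@H]3CCN(C)C[C@H]3O)c(O)cc(O)c2c(=O)c1C(O)c1c(Cl)cccc1Cl`) gives 33% and compound 3 (`Cc1oc2c([C@H]3CCN(C)C[C@H]3O)c(O)cc(O)c2c(=O)c1C(O)c1csc([N+](=O)[O-])c1`) gives 20%, the second highest of the three numbers. Compound 4 (`COc1ccc(C(O)c2c(C)oc3c([C@H]4CCN(C)C[C@H]4O)c(O)cc(O)c3c2=O)cc1Br`) has 3-bromo-4-methoxyphenyl in place of 5-nitrothiophen-3-yl on a saturated chain carbon bound to an aromatic carbon and an oxygen on a saturated carbon.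

Three measured steps at this place bear on the change: a number 27 percentage points higher from compound 1 to compound 2 (beyond the scatter), a number 14 percentage points higher from compound 1 to compound 3 (beyond the scatter) and a number 13 percentage points lower from compound 2 to compound 3 (beyond the scatter). All are modest, and they run in both directions. Among the compounds with values here, none of the measured compounds carries bromo or methoxy, so the direction of the new step is not set by the data. The value of compound 3 lies inside the span of the two chlorinated phenyl compounds, so no step beyond the scatter is expected. The estimated change is a number 2 percentage points lower from compound 3 to compound 4 (within the scatter). For compound 4 the expected value is 18%, with an estimated range of 4% to 38%.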

Compound 4, percent growth inhibition at one concentration: 41%
Compound 4: the middle estimate sits 23 percentage points below what was measured, and the stated range ends below it.
By their numbers in this assay, from the lowest: compound 1; then compound 3; then compounds 2 and 4 (each within the scatter of the next).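

In this assay, within the data shown here, the aryl group on a saturated chain carbon bound to an aromatic carbon and an oxygen on a saturated carbon tolerates a phenyl ring carrying both bromo and methoxy: the change gives a number 21 percentage points higher from compound 3 to compound 4 (beyond the scatter) and, against the 4-chlorophenyl compound, a number 35 percentage points higher from compound 1 to compound 4 (beyond the scatter), the only large step at this place so far. The step to the 2,6-dichlorophenyl compound is a number 8 percentage points higher from compound 2 to compound 4 (within the scatter), so two differently substituted phenyl groups stand level here, and a phenyl ring as such does not fix the number, since 4-chlorophenyl gives the lowest value of the series. Nothing at hand accounts for these differences.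

On these data alone, what the bromo and the methoxy each contribute alone stays open. So does how a phenyl ring bearing a dimethylamino group or a carboxylic acid would read at this place.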